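A few compounds are considered here, and "the series" means these few. Any claim that something is new, unique, unknown or untested is made for them only; others in the source may bear on it.

Values in a functional assay on CCRF-CEM cells (Homo sapiens), read by MTT assay, with a stated time of 72 h (a higher number here means a weaker inhibitor, a lower number a stronger inhibitor), for the three measured compounds:

- compound 1 `CSc1ncnc2c1c(-c1ccsc1)cn2[C@@H]1O[C@H](CO)[C@@H](O)[C@H]1O` gives > 20000 nM as a limit
- compound 2 `O=c1[nH]cnc2c1c(-c1ccccc1)cn2[C@@H]1O[C@H](CO)[C@@H](O)[C@H]1O` gives > 100000 nM as a limit
- compound 3 `Nc1nc2c(c(-c3ccoc3)cn2[C@@H]2O[C@H](CO)[C@@H](O)[C@H]2O)c(=O)[nH]1` gives 17900 nM as a number

Compound 3 is the only one of the three with an actual number, since the other two readings stop at a limit. It therefore serves as the single numerical reference point.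

The step of interest leads to compound 4 `Nc1nc2c(c(-c3ccccc3)cn2[C@@H]2O[C@H](CO)[C@@H](O)[C@H]2O)c(=O)[nH]1`, which has phenyl in place of furan-3-yl on an aromatic carbon and keeps the rest of compound 3 unchanged. Compound 2 also carries phenyl, on a different core, and its reading of > 100000 nM is a limit. In this assay, among the compounds with values here, no step clearly beyond the scatter is expected, if anything a slight drift towards a weaker value, and a limit alone is quite possible. The estimated change is a 1.4-fold higher number from compound 3 to compound 4 (0.15 log units; within the scatter) as an expectation only. For compound 4 the expected value is 25000 nM by estimate, with a likely range from 8000 nM to 80000 nM when it is measured.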

Compound 4, half-maximal inhibitory concentration: > 100000 nM
Compound 4 gave a limit, no number (the forecaster's own chance of this, stated with the estimate: 45%); at least 4.0-fold (0.60 log units) between middle value and limit.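

In this assay, within the data shown here, phenyl in place of furan-3-yl on an aromatic carbon gives an at least 5.5-fold higher number from compound 3 to compound 4 (0.74 log units; beyond the scatter), the first step in this set that can be read. On the core shared by these two compounds, this position therefore does not treat the two aromatic rings alike, and the furan-3-yl compound is the one that keeps a measurable number. The reading of compound 4 is a limit, so the full size of the step remains unknown: the limit of > 100000 nM in this assay, at which 2 of the 4 values shown sit.

From the compounds shown here alone, the step from compound 2 to compound 4 cannot be read, as both values are limits, so what the amino group contributes stays open. Going by these compounds, it is also open whether a carboxylic acid or an aminomethyl group at this aromatic carbon would give a number in this assay.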